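This account rests on a few compounds, and the source may have more. Where it says the series, first, only, none or still open, it means among the compounds named here.

In a functional assay on HT-29 cells (Homo sapiens) for antiproliferative activity, with a stated time of 48 h (on this read-out lower numbers stand for an effect already at smaller amounts and higher numbers for an effect only at larger amounts of compound), compound 1 (`O=C(CCCCCCC(=O)Nc1cccc(C(F)(F)F)c1)NO`) gives 6400 nM and compound 3 (`O=C(CCCCCCC(=O)Nc1ccccc1Br)NO`) gives 17000 nM, while compound 2 (`O=C(CCCCCCC(=O)Nc1ccc(C(F)(F)F)cc1)NO`) gives 1400 nM as the lowest of the three numbers, separated from both others by more than the usual scatter. Compound 4 (`N#Cc1ccc(NC(=O)CCCCCCC(=O)NO)cc1`) differs from compound 2 in one place, with cyano in place of trifluoromethyl on an aromatic carbon, para to a large group (cyano in place of trifluoromethyl on an aromatic carbon). Among the compounds with values here, no measured pair shows this swap, so the expectation rests on the structural change alone. In this assay a small upward step in the number is expected (a 1.8-fold higher number from compound 2 to compound 4 (0.25 log units; within the scatter)), one that may well stay within the scatter. For compound 4 the estimated value is 2500 nM (expected range 800 nM to 7500 nM).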

Compound 4, half-maximal effective concentration: 42000 nM
Compound 4: middle estimate off by 17-fold (1.23 log units), on the low side, outside the stated range (above it).
By their numbers in this assay, from the lowest: compound 2; then compound 1; then compound 3; then compound 4.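

In this assay, this first step between compounds that differ in one place gives a 30-fold higher number from compound 2 to compound 4 (1.48 log units; beyond the scatter), for cyano in place of trifluoromethyl on an aromatic carbon para to a large group. At this position, then, the two groups are far from interchangeable, although the swap changes only a small substituent. Nothing measured here explains the size of this step.

Going by these compounds, whether an amine, a methoxy group or a chlorine atom at this place would behave like trifluoromethyl or like cyano stays open. So does the effect of cyano on other aromatic carbons.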